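A few compounds are considered here, and "the series" means these few. Any claim that something is new, unique, unknown or untested is made for them only; others in the source may bear on it.

Series in a functional assay on HepG2 cells (Homo sapiens) for cytotoxicity, read by colorimetric assay and neutral red uptake, with a stated time of 72 h; a lower number here means a stronger inhibitor, a higher number a weaker inhibitor:
- compound 1 `CO[C@@H](C(=O)N[C@H]1CCCCNC1=O)[C@@H]1OC(C)(C)O[C@H](/C=C/C(C)(C)C)[C@@H]1O`: > 150000 nM, a limit of the assay and not a number
- compound 2 `CO[C@@H](C(=O)N[C@@H]1CCCCNC1=O)[C@H](O)[C@@H](O)[C@H](O)/C=C/C(C)(C)C`: 1100 nM
- compound 3 `CO[C@@H](C(=O)N[C@H]1CC[C@H](O)CNC1=O)[C@H](O)[C@@H](O)[C@H](O)/C=C/C(C)(C)C`: 103000 nM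
- compound 4 `CO[C@@H](C(=O)N[C@@H]1CC[C@H](O)CNC1=O)[C@H](O)[C@@H](O)[C@H](O)/C=C/C(C)(C)C`: not yet measured

Compound 2 holds the lower of the two actual numbers, well beyond the scatter from compound 3. The change to compound 4 is hydroxy in place of hydrogen on a saturated ring carbon, in words hydroxy in place of hydrogen on a saturated ring carbon. Among the measured compounds shown here, the one measured step that bears on it is a 94-fold higher number from compound 2 to compound 3 (1.97 log units; beyond the scatter), a large step with 6-hydroxy-2-oxoazepan-3-yl in place of 2-oxoazepan-3-yl. Compound 3 and compound 4 are, however, drawn with opposite configuration at the ring atom that bears a large group, and compound 4 matches compound 2 there. The step may therefore not carry over in full. In this assay a higher number is expected, but a smaller rise, with the estimate being a 5.5-fold higher number from compound 2 to compound 4 (0.74 log units; beyond the scatter). For compound 4 the expected value is 6000 nM, with an estimated range of 500 nM to 70000 nM.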

Compound 4, half-maximal inhibitory concentration: 138000 nM
For compound 4 the middle estimate is 23-fold (1.36 log units) below the measured one; measured number outside the range, above it.
By their numbers in this assay, from the lowest: compound 2; then compounds 3 and 4 (each within the scatter of the next). At a limit, above all of these: compound 1.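

In this assay, hydroxy in place of hydrogen on the saturated ring carbon, two ring bonds from the ring nitrogen, gives a 130-fold higher number from compound 2 to compound 4 (2.10 log units; beyond the scatter), so a large step now also appears with the ring atom that bears a large group drawn as in compound 2. The configuration at that ring atom does not separate the two hydroxy compounds in this assay, with a 1.3-fold higher number from compound 3 to compound 4 (0.13 log units; within the scatter), and this pair isolates that single difference: the fact that compounds 3 and 4 differ only in the configuration as drawn.

Still open, on these data alone, is whether the step belongs to hydroxy itself or would also follow a methoxy group, an amine or a fluorine on this ring carbon. Also open, as far as these compounds go, is the effect of the opposite configuration at the ring atom that bears a large group when this ring carbon carries only hydrogen and the rest of compound 2 is kept.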